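Swapping a Bromophenyl for a Bromothiophene on the Sulfonyl

The source may report more compounds than this note shows. Statements on the series, on what has been measured and on what is new or still open speak of the compounds shown alone.

Of the compounds shown here, three sharing one core have been tested in a functional assay on SUP-B15 cells (Homo sapiens) for antiproliferative activity, with a stated time of 72 h (a higher number here means that more compound is needed for the effect, a lower number that less compound is needed), and all of them need a great deal of material to slow cell growth. Compound 1 `COc1ccc(-c2cc(=O)c3c(OC)cc(OC)cc3n2S(=O)(=O)c2ccc(C=O)cc2)cc1` reaches only a limit of the assay, > 34400 nM. Compound 2 `COc1ccc(-c2cc(=O)c3c(OC)cc(OC)cc3n2S(=O)(=O)c2ccc([N+](=O)[O-])cc2)cc1` gives a number, 17100 nM, which amounts to an at least 2.0-fold lower number from compound 1 to compound 2 (0.30 log units; that floor lies within the scatter). Compound 3 `COc1ccc(-c2cc(=O)c3c(OC)cc(OC)cc3n2S(=O)(=O)c2cccc(Br)c2)cc1` again gives no number but a limit, > 58600 nM. Compound 3 thus stands at the weak end of what is shown. The comparison a step that the two limits leave unreadable from compound 1 to compound 3 cannot be read because the limit of > 34400 nM in this assay, at which 1 of the 3 values shown sits, and the limit of > 58600 nM in this assay, at which 1 of the 3 values shown sits, are both limits rather than numbers. Against compound 2, however, the step is an at least 3.4-fold higher number from compound 2 to compound 3 (0.53 log units; beyond the scatter).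

Compound 4 `COc1ccc(-c2cc(=O)c3c(OC)cc(OC)cc3n2S(=O)(=O)c2ccc(Br)s2)cc1` has not been measured. It differs from compound 3 in one place: 5-bromothiophen-2-yl in place of 3-bromophenyl on a sulfonyl sulfur. Within the data shown here, none of the measured steps exchanges one aromatic ring for another on the sulfonyl sulfur; they alter only the group carried on a phenyl ring, so they give little guidance for this change. With compound 3 already at a limit, the expected step is a step that the limit leaves unreadable from compound 3 to compound 4, meaning no movement beyond the scatter. Compound 4 is therefore expected to give around 60000 nM, within a range from 20000 nM to 150000 nM, with a fair chance that this assay again reports only a limit.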

Compound 4, half-maximal effective concentration: > 48200 nM
Compound 4 was reported as a limit; the forecaster's own chance of this, stated with the estimate: 60%; the middle value is on the limit's open side.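

With the 5-bromothiophen-2-yl group on the sulfonyl sulfur, compound 4 gives > 48200 nM in this assay, which is a limit and not a number. Compound 3, with its 3-bromophenyl group, also ended at a limit, so both bromine-bearing rings shown give no measurable value here, as does the 4-formylphenyl group of compound 1, while the 4-nitrophenyl group of compound 2 alone gives a number; against that one number, the step is an at least 2.8-fold higher number from compound 2 to compound 4 (0.45 log units; beyond the scatter). The steps to compound 4 from compound 1 and from compound 3 cannot be read because both ends of each step are limits, as with the new one: the limit of > 48200 nM in this assay, at which 1 of the 4 values shown sits.

As far as these compounds go, the true size of the exchange of a phenyl ring for a thiophene ring therefore stays open, and so does whether the thiophene ring could give a number with something other than bromine on it. From the compounds shown here alone, it also remains open how an amine or a carboxylic acid in place of that bromine would read in this assay.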